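The source may hold more compounds than are shown below. What is called first, only, known or untested is meant among the compounds shown, and "the series" means these compounds.

Measured so far in a functional assay on NCI-H460 cells (Homo sapiens) for inhibition, read by MTT assay, with a stated time of 72 h; on this read-out higher numbers stand for weaker inhibition of growth and lower numbers for stronger inhibition of growth:
compound 1, `CC(C)(C)c1ccc(CNCCCNS(=O)(=O)c2cc(C(F)(F)F)cc(C(F)(F)F)c2)cc1`, gives 2500 nM
compound 2, `O=S(=O)(NCCNCc1ccc(-c2ccccc2)cc1)c1cc(C(F)(F)F)cc(C(F)(F)F)c1`, gives 2600 nM
compound 3, `COc1ccc(CNCCCNS(=O)(=O)c2cc(C(F)(F)F)cc(C(F)(F)F)c2)cc1OC`, gives 2400 nM

Compound 1 stands second highest of the three numbers, with compound 2 and compound 3 on either side of it, all within the scatter of one another. Compound 4, `O=S(=O)(NCCCNCc1ccc(-c2ccccc2)cc1)c1cc(C(F)(F)F)cc(C(F)(F)F)c1`, is not yet measured. It differs from compound 1 by phenyl in place of tert-butyl on an aromatic carbon. Going by the values given here, the one step that touches the same carbon of the series, a 1.0-fold lower number from compound 1 to compound 3 (0.02 log units; within the scatter), changed nothing beyond the scatter. Compound 2, which carries the same biphenyl group as compound 4 on a shorter chain, sits at a number indistinguishable from compound 1. Among the compounds with values here, no step in this set has moved the read-out beyond the scatter, so for compound 4 no step beyond the scatter is expected in this assay, no change at the digits printed from compound 1 to compound 4 (within the scatter). Compound 4 is estimated at 2500 nM, between 1200 nM and 5200 nM.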

Compound 4, concentration for 50% growth inhibition: 2500 nM
The estimate for compound 4 equals the measured number at the digits printed; the measured number falls inside the stated range.
By their numbers in this assay, from the lowest: compounds 3, 1, 4 and 2 (each within the scatter of the next).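

In this assay, the change at this aromatic carbon, para to a large group, gives no change at the digits printed from compound 1 to compound 4 (within the scatter). A phenyl ring here therefore reads the same as the tert-butyl group, so a group without a ring and a six-membered aromatic ring of carbon only are not told apart at this carbon on the longer-chain compounds shown. No measured evidence accounts for this result.

Still open, from the compounds shown here alone, is whether a carboxylic acid or an amine on this aromatic carbon would move the growth-inhibition number beyond the scatter. Going by these compounds, a longer chain also remains untested within these compounds.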